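The source may report more compounds than this note shows. Statements on the series, on what has been measured and on what is new or still open speak of the compounds shown alone.

In an ADME assay on microsomes from liver (Mus musculus) for metabolic stability, read by LC-MS, using NADPH, with a stated time of 10 min, tested at 0.1 uM (on this read-out lower numbers stand for slow clearance and higher numbers for fast clearance), compound 1 `Cc1cccc(N2C(=O)CSC2c2cccc(C(=O)NCCCCc3ccccc3)c2)c1` gives 2940 mL.min-1.g-1, and compound 2 `C#Cc1cccc(N2C(=O)CSC2c2cccc(C(=O)NCCCCc3ccccc3)c2)c1` gives 1900 mL.min-1.g-1. Within the data shown here, compound 2 therefore stands within the usual scatter of compound 1, the only other compound measured. The next compound is compound 3 `O=C(NCCCCc1ccccc1)c1cccc(C2SCC(=O)N2c2cccc(F)c2)c1`, which keeps the rest of compound 2 and carries fluoro in place of ethynyl on an aromatic carbon, meta to a large group: fluoro in place of ethynyl on an aromatic carbon. Among the measured compounds shown here, one measured step bears on this change, the exchange of methyl for ethynyl at the same place, which gave a 1.5-fold lower number from compound 1 to compound 2 (0.19 log units; within the scatter). From the compounds shown here alone, that step stayed within the scatter, so no shift beyond the scatter is expected in this assay, though a single step is thin evidence and fluoro itself is untested here. The expected change is a 1.2-fold higher number from compound 2 to compound 3 (0.08 log units; within the scatter). For compound 3 the estimated value is 2300 mL.min-1.g-1, with an expected range from 1100 mL.min-1.g-1 to 4600 mL.min-1.g-1.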

Compound 3, intrinsic clearance in microsomes: 2740 mL.min-1.g-1
For compound 3 the middle estimate is 1.2-fold (0.08 log units) below the measured one; the measured number falls inside the stated range.
By their numbers in this assay, from the lowest: compounds 2, 3 and 1 (each within the scatter of the next).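

In this assay fluoro in place of ethynyl gives a 1.4-fold higher number from compound 2 to compound 3 (0.16 log units; within the scatter) and fluoro in place of methyl gives a 1.1-fold lower number from compound 1 to compound 3 (0.03 log units; within the scatter) and so both steps stay within the scatter. Among these compounds, the earlier compounds offered only one exchange on this aromatic carbon; with a third group in hand, methyl, ethynyl and fluoro all lie within the scatter of one another, so these three groups do not separate the compounds in this read-out. No measurement shown here accounts for that.

From the compounds shown here alone, what an amine, a carboxylic acid or a methoxy group would do at this place remains open, including whether any of them would lead to a step beyond the scatter. The shared core and the amide chain are the same in all three compounds, so the effect of a shorter chain there is open too.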